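Acetyl Lessons Applied to a Methylcarbamoyl Analogue

The source may report more compounds than this note shows. Statements on the series, on what has been measured and on what is new or still open speak of the compounds shown alone.

Of the compounds shown here, three on one shared core have been tested in a functional assay on the whole organism for inhibition, with Rattus norvegicus as the target; on this read-out higher numbers stand for an effect only at larger amounts of compound and lower numbers for an effect already at smaller amounts. Compound 1 `Cc1ccc(N/N=C2\CCC(C)n3c2ncc(C(=O)O)c3=O)cc1` gives 1.3 umol/kg. Compound 2 `CC(=O)c1ccc(N/N=C2\CCC(C)n3c2ncc(C(=O)O)c3=O)cc1` gives 9.5 umol/kg, and compound 3 `CC(C)c1ccc(N/N=C2\CCC(C)n3c2ncc(C(=O)O)c3=O)cc1` gives 2.4 umol/kg, the second highest of the three numbers. The two steps that bring in or remove acetyl, a 7.3-fold higher number from compound 1 to compound 2 (0.86 log units; beyond the scatter) and a 4.0-fold lower number from compound 2 to compound 3 (0.60 log units; beyond the scatter), both lie beyond the scatter, whereas a 1.8-fold higher number from compound 1 to compound 3 (0.27 log units; within the scatter) stays within it. Compound 4 `CNC(=O)c1ccc(N/N=C2\CCC(C)n3c2ncc(C(=O)O)c3=O)cc1` differs from compound 3 by methylcarbamoyl in place of isopropyl on an aromatic carbon; like acetyl, methylcarbamoyl carries a carbonyl, so those two steps are the ones that bear on it. A modest rise in this assay is therefore expected, a 3.8-fold higher number from compound 3 to compound 4 (0.57 log units; beyond the scatter). Compound 4 is estimated at 9 umol/kg, within 3 umol/kg to 30 umol/kg.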

Compound 4, dose for 50% inhibition: 9.6 umol/kg
Compound 4: middle estimate off by 1.1-fold (0.03 log units), on the low side, and the stated range covers the measured number.
By their numbers in this assay, from the lowest: compounds 1 and 3 (each within the scatter of the next); then compounds 2 and 4 (each within the scatter of the next).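

In this assay the swap of methyl for methylamino on the carbonyl carbon leaves the number where it was (a 1.0-fold higher number from compound 2 to compound 4 (0.00 log units; within the scatter)), so the added amide hydrogen brings no readable change. At this place, para to a large group, methylcarbamoyl stands apart from both isopropyl (a 4.0-fold higher number from compound 3 to compound 4 (0.60 log units; beyond the scatter)) and methyl (a 7.4-fold higher number from compound 1 to compound 4 (0.87 log units; beyond the scatter)), just as acetyl does. No measurement here explains why these two carbonyl groups go with higher numbers.

From the compounds shown here alone, whether the carbonyl itself matters remains open. An amine or a nitrile at this place, or a longer chain on the amide nitrogen, would test this.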